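The source may report more compounds than this note shows. Statements on the series, on what has been measured and on what is new or still open speak of the compounds shown alone.

Measured in a functional assay on CCRF-CEM cells (Homo sapiens) for cytotoxicity, in the absence of a further agent; a higher number here means a weaker inhibitor, a lower number a stronger inhibitor:
- compound 1 `Nc1nc(N)c(CCCN(Cc2ccc(NC(CCC(=O)O)C(=O)O)cc2)c2cc(F)c([N+](=O)[O-])cc2[N+](=O)[O-])c(O)n1`: 51000 nM
- compound 2 `Nc1nc(N)c(CCCN(Cc2ccc(NC(CCC(=O)O)C(=O)O)cc2)c2ccc([N+](=O)[O-])c(F)c2F)c(O)n1`: > 100000 nM

Compound 2 gives no number, and its > 100000 nM is a limit of the assay. It sits at the limit of > 100000 nM in this assay, at which 1 of the 2 values shown sits.

Compound 3 `Nc1nc(N)c(CCCN(Cc2ccc(NC(CCC(=O)O)C(=O)O)cc2)c2cc(F)ccc2[N+](=O)[O-])c(O)n1` carries 5-fluoro-2-nitrophenyl in place of 2,3-difluoro-4-nitrophenyl on an amine nitrogen. The rest of the structure stays as in compound 2.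

For the measured compounds named here, no measured step in this assay is available to scale this change. Going by the values given here, the only numerical reading is compound 1 at 51000 nM, so compound 3 is expected to stay weak, and a step beyond the scatter is not expected. The expected move is an at least 1.1-fold lower number from compound 2 to compound 3 (0.04 log units; that floor lies within the scatter). A reading at the assay limit would be no surprise. For compound 3 the estimated value is 90000 nM, with an expected range of 35000 nM to 200000 nM.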

Compound 3, half-maximal inhibitory concentration: > 100000 nM
Compound 3 ended at the assay's limit (the forecaster's own chance of this, stated with the estimate: 55%); at least 1.1-fold (0.04 log units) between middle value and limit.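

In this assay, for the compounds shown here, hydrogen in place of nitro on an aromatic carbon gives the only readable one-place step in this set: an at least 1.9-fold higher number from compound 1 to compound 3 (0.29 log units; that floor lies within the scatter). Since this floor does not clear the scatter, the loss of that nitro group cannot yet be called a real change, although the step does show that the reading for compound 1 is not kept. The step from compound 2 to compound 3 cannot be read, so 5-fluoro-2-nitrophenyl and 2,3-difluoro-4-nitrophenyl cannot be ranked, and most of the set now gives no number: the limit of > 100000 nM in this assay, at which 2 of the 3 values shown sit.

From the compounds shown here alone, how far the true values of compound 2 and compound 3 lie beyond the limit remains open. Also open, going by these compounds, is whether an amine or a chlorine in place of that nitro group would bring a reading inside the range of the assay.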